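Sulfonamide aryl swap: from dimethylphenyl to chlorophenyl

The compounds below may be only part of what the source reports. "The series", "measured", "known", "first", "only" and "open" are said of these compounds alone.

Compound 1 `CC(C)Cc1ccc(NS(=O)(=O)c2ccc(N3CCNC3=O)cc2)cc1`: > 1000 nM
Compound 2 `Cc1ccc(NS(=O)(=O)c2ccc(N3CCNC3=O)cc2)cc1C`: 94 nM

Going by the values given here, in a functional assay on M21 cells (Homo sapiens) for antiproliferative activity, read by sulforhodamine B assay, with a stated time of 48 h (a higher number here means a weaker inhibitor, a lower number a stronger inhibitor), compound 2 gives 94 nM, the only number among the values shown. For compound 1 this assay reports only a limit, > 1000 nM, rather than a number; it is one of two values shown, and one of them sits at the limit of > 1000 nM in this assay, at which 1 of the 2 values shown sits. Among the compounds with values here, no measured pair that differs in a single place is available, so no measured step can guide the next change.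

Compound 3 `O=C1NCCN1c1ccc(S(=O)(=O)Nc2ccc(Cl)cc2)cc1` is not yet measured in this assay. It differs from compound 2 by 4-chlorophenyl in place of 3,4-dimethylphenyl on a sulfonamide nitrogen. The change exchanges one carbon-only aromatic ring for another of similar size, with no donors or acceptors entering or leaving. Compound 2 and compound 3 are expected to differ by a step of a 2.7-fold higher number from compound 2 to compound 3 (0.42 log units; beyond the scatter), modestly toward weaker inhibition and close to the scatter. Compound 3 is therefore estimated at 250 nM, in a range from 60 nM to 1200 nM.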

Compound 3, half-maximal inhibitory concentration: 90 nM
Compound 3: the middle estimate sits 2.8-fold (0.44 log units) above what was measured; the range from low to high includes it.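

In this assay, 4-chlorophenyl and 3,4-dimethylphenyl on the sulfonamide nitrogen cannot be told apart: a 1.0-fold lower number from compound 2 to compound 3 (0.02 log units; within the scatter). Within these compounds, the two differently substituted phenyl groups therefore read alike, whereas chloro in place of isobutyl on an aromatic carbon gives a large step: an at least 11-fold lower number from compound 1 to compound 3 (1.04 log units; beyond the scatter). That step has only a lower bound, since compound 1 is reported as a limit and not as a number: the limit of > 1000 nM in this assay, at which 1 of the 3 values shown sits.

The compounds shown leave open whether a methoxy or fluoro group on this phenyl ring, or a pyridyl ring in its place, would read like compound 3. They also leave open whether an ethyl or propyl chain in place of the chloro would read like compound 3 or like compound 1.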